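Compound 3: an estimate from one measured step

A few compounds are considered here, and "the series" means these few. Any claim that something is new, unique, unknown or untested is made for them only; others in the source may bear on it.

Compound 1 (`CCOc1ccccc1-c1ccc(-c2nc3cnccc3c(N[C@H](CC)C(=O)NS(C)(=O)=O)c2C#N)cc1`) reads 2.2 in a physicochemical assay for lipophilicity, read by HPLC, at pH 7.5 (a lower number here means a more polar compound, a higher number a more lipophilic compound), and compound 2 (`CCOc1ccccc1-c1ccc(-c2nc3cnccc3c(N[C@H](CC)C(=O)O)c2C#N)cc1`) reads 2.1 in the same measurement, so compound 2 stands level with compound 1 within the scatter. For the measured compounds named here, the one measured step (a number 0.10 log units lower from compound 1 to compound 2 (within the scatter)) puts hydroxy in place of methanesulfonamido on a carbonyl carbon. Compound 3 (`CCOc1ccccc1-c1ccc(-c2nc3cnccc3c(N[C@H](CC(C)C)C(N)=O)c2C#N)cc1`) carries a different change (1-carbamoyl-3-methylbutyl in place of 1-carboxypropyl on a nitrogen on an aromatic ring) with 1-carbamoyl-3-methylbutyl in place of 1-carboxypropyl on a nitrogen on an aromatic ring. Going by the values given here, the measured step bears on this only in part, and no measured pair contains 1-carbamoyl-3-methylbutyl. The expected step (a number 1.40 log units higher from compound 2 to compound 3 (beyond the scatter)) is upward and beyond the scatter, a judgement resting on the structural change alone and held loosely. Compound 3 is expected at 3.5 within an estimated range of 2.8 to 4.2 on this assay readings.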

Compound 3, distribution coefficient: 3.4
Compound 3: middle estimate off by 0.10 log units, on the high side, and the stated range covers the measured number.
By their numbers in this assay, from the lowest: compounds 2 and 1 (each within the scatter of the next); then compound 3.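

Changing the group on a nitrogen on an aromatic ring moves the number in this assay, giving a number 1.30 log units higher from compound 2 to compound 3 (beyond the scatter) and a number 1.20 log units higher from compound 1 to compound 3 (beyond the scatter); both steps lie beyond the scatter, unlike the earlier change on a carbonyl carbon, which gave a number 0.10 log units lower from compound 1 to compound 2 (within the scatter). The entering 1-carbamoyl-3-methylbutyl differs from 1-carboxypropyl in both its chain and its carbonyl end, so these steps cannot be divided between the two parts. No measurement given here accounts for the rise.

Open, from the compounds shown here alone, is how much each part contributes: a 1-carbamoylpropyl or a 1-carboxy-3-methylbutyl group on the same nitrogen would separate them. Also open, going by these compounds, is how an amine in place of the carbamoyl group, or a longer chain, would read at this position.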